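Lengthening the alkoxy chain: ethoxy to propoxy

A few compounds are considered here, and "the series" means these few. Any claim that something is new, unique, unknown or untested is made for them only; others in the source may bear on it.

Within the data shown here, in a functional assay on the whole organism (strain Sprague-Dawley) for inhibition, with Rattus norvegicus as the target, with a stated time of 10 min (a lower number here means that less compound is needed, a higher number that more compound is needed for the effect), compound 2 (`CCOc1ccccc1-c1ncc(C(=O)O)c(=O)[nH]1`) gives 0.5 mg/kg, the lowest of the two numbers so far, and compound 1 (`COc1ccccc1-c1ncc(C(=O)O)c(=O)[nH]1`) gives 10 mg/kg. Compound 3 (`CCCOc1ccccc1-c1ncc(C(=O)O)c(=O)[nH]1`) has not yet been measured. Its difference from compound 2 is methyl in place of hydrogen on a saturated chain carbon, two bonds along the chain from an oxygen on an aromatic ring, which reads as ethoxy to propoxy. Among the measured compounds shown here, only one measured step bears on this change. It is a 20-fold lower number from compound 1 to compound 2 (1.30 log units; beyond the scatter), where methyl takes the place of hydrogen on a saturated chain carbon bound to that oxygen. This step lies beyond the scatter, but a single step gives no trend, and nothing yet shows whether the drop continues with a further carbon. On the strength of a 20-fold lower number from compound 1 to compound 2 (1.30 log units; beyond the scatter), a much smaller move in the same direction is expected in this assay, possibly within the scatter. The expected change is a 1.7-fold lower number from compound 2 to compound 3 (0.22 log units; within the scatter). Compound 3 is estimated at 0.3 mg/kg, with an expected range of 0.06 mg/kg to 1.5 mg/kg.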

Compound 3, dose for 50% inhibition: 0.9 mg/kg
The estimate for compound 3 lay 3.0-fold (0.48 log units) below the measured number; low and high end bracket the measured number.
By their numbers in this assay, from the lowest: compounds 2 and 3 (each within the scatter of the next); then compound 1.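

In this assay, the further carbon gives a 1.8-fold higher number from compound 2 to compound 3 (0.26 log units; within the scatter), so ethoxy to propoxy does not repeat the large step seen on going from methoxy to ethoxy, a 20-fold lower number from compound 1 to compound 2 (1.30 log units; beyond the scatter), and the two longer chains cannot be told apart at this position. The gain over methoxy survives the added carbon, with an 11-fold lower number from compound 1 to compound 3 (1.05 log units; beyond the scatter), so among these three compounds the large difference lies between methoxy and the two longer chains, while the change on the carbon two bonds along the chain from the oxygen stays within the scatter. Nothing on hand accounts for this levelling of the series.

The compounds shown leave open whether butoxy or a still longer chain would stay within the scatter of compound 2 and compound 3 or move beyond it, so three points do not yet define how far this plateau extends. They also leave open whether a branched chain such as isopropoxy, or an amine in place of the alkoxy chain, would fit the same picture.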